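Chloro Substitution on the Amide Aryl Ring and Growth Inhibition

A few compounds are considered here, and "the series" means these few. Any claim that something is new, unique, unknown or untested is made for them only; others in the source may bear on it.

The account starts from compound 1 `O=C(CCCCC(S)CCS)Nc1ccccn1`, which in a functional assay on Bel-7402 cells (Homo sapiens) for inhibition, read by MTT assay, with a stated time of 24 h, tested at 100 ug/mL (a higher number here means more inhibition of growth at the concentration tested, a lower number less inhibition of growth), gives 3.62%. Compound 2 `O=C(CCCCC(S)CCS)Nc1ccc(Cl)cn1`, which carries chloro in place of hydrogen on an aromatic carbon, gives 50.7% in this assay, so that the step of a number 47.1 percentage points higher from compound 1 to compound 2 (beyond the scatter). Compound 3 `CC(=O)SCCC(CCCCC(=O)Nc1ccccc1)SC(C)=O` has a different core; the difference between the two cores of compound 1 and compound 3 is not broken down here. In this assay compound 3 gives 14.1%, which stands second highest of the three numbers. Compound 4 `CC(=O)SCCC(CCCCC(=O)Nc1ccccc1Cl)SC(C)=O` is not yet measured and differs from compound 3 by chloro in place of hydrogen on an aromatic carbon. This is the same kind of change as that from compound 1 to compound 2, not the same: there the chloro sits on a six-membered aromatic ring with one nitrogen, two atoms from the ring nitrogen and para to a large group, whereas in compound 4 it sits on a six-membered aromatic ring of carbon only, ortho to a large group. On the strength of a number 47.1 percentage points higher from compound 1 to compound 2 (beyond the scatter) a rise is expected for compound 4, but a smaller step of a number 20.9 percentage points higher from compound 3 to compound 4 (beyond the scatter) is estimated, since the core and place differ. Compound 4 is expected to give about 35% in this assay, estimated to lie between 10% and 65%.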

Compound 4, percent growth inhibition at one concentration: "not active" (no number reported)
The entry for compound 4 holds no number; no gap can be computed for the estimate.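

For the compounds shown here, compound 4 is recorded as "not active" in this assay with no number reported, so no step from compound 3 to compound 4 can be read. Nothing shown here bears on this result. The compounds shown leave open how the change from phenyl to 2-chlorophenyl on the core of compound 3 compares numerically with the step seen between compound 1 and compound 2.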